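Capping the chain end of a lactone with an ester

This account rests on a few compounds, and the source may have more. Where it says the series, first, only, none or still open, it means among the compounds named here.

Compound 1, `CC(C)(C)C(=O)OCC1(CO)C/C(=C\CCCCCCCCCCCO)C(=O)O1`, was tested in a functional assay on COLO 205 cells (Homo sapiens) for antiproliferative activity (a higher number here means a weaker inhibitor of growth, a lower number a stronger inhibitor of growth), where it gives 2.49 ug/mL. Going by the values given here, that is the higher of the two numbers measured so far. Among the compounds with values here, the only other measured compound, compound 2, `COCCCCCCCCCCCCCCC/C=C1/CC(CO)(COC(=O)C(C)(C)C)OC1=O`, gives 0.178 ug/mL in this assay, a lower number and therefore a stronger inhibitor of growth.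

Compound 3, `CC(C)(C)C(=O)OCCCCCCCCCCCCCCC/C=C1\CC(CO)(COC(=O)C(C)(C)C)OC1=O`, has not yet been measured in this assay. It differs from compound 1 in one place: 4-(((tert-butyl)carbonyl)oxy)butyl in place of hydroxy on a saturated chain carbon, ten or more bonds along the chain from a double-bonded chain carbon. The free hydroxy group at the far end of the chain is gone, and in its place the chain ends in an ester.

Compound 2 shows that a chain without the free hydroxy group can come with a far lower number, so a step downward is expected for compound 3 as well. The expected step is a 7.1-fold lower number from compound 1 to compound 3 (0.85 log units; beyond the scatter), well beyond the usual scatter. On that basis compound 3 is estimated to give 0.35 ug/mL in this assay, with a range from 0.08 ug/mL to 1.5 ug/mL.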

Compound 3, concentration for 50% growth inhibition: 0.597 ug/mL
The estimate for compound 3 lay 1.7-fold (0.23 log units) below the measured number; the measured number falls inside the stated range.
By their numbers in this assay, from the lowest: compound 2; then compound 3; then compound 1.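

In this assay the far end of the chain accepts a large change, as swapping hydroxy for 4-(((tert-butyl)carbonyl)oxy)butyl gives a 4.2-fold lower number from compound 1 to compound 3 (0.62 log units; beyond the scatter). Going by these compounds alone, this is the first step read between two compounds that differ in one place, and it lies beyond the usual scatter, so for this pair a free hydroxy group at the far end of the chain is not needed for growth inhibition; its replacement goes with a stronger inhibitor. Nothing measured here speaks to why the number falls.

The change also does two things at once, extending the chain by a butyl stretch and capping its end with an ester, so this single step cannot say how much of the drop belongs to each part. A 4-hydroxybutyl group or a plain butyl group at this place would separate the two, and an amine or a carboxylic acid at the chain end would show how far the position accepts other kinds of group.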